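The source may hold more compounds than are shown below. What is called first, only, known or untested is meant among the compounds shown, and "the series" means these compounds.

Of the compounds shown here, two built on one shared core have been tested in a functional assay on NCI-H23 cells (Homo sapiens) for inhibition, read by sulforhodamine B assay, with a stated time of 48 h; a higher number here means that more compound is tolerated, a lower number that less compound is tolerated. Compound 1 `Nc1cc(N)c2nc(-c3ccccc3)c(NCc3ccc(Cl)c(Cl)c3)nc2c1` gives 55000 nM in this assay, which is the lowest of the two numbers; compound 2 `CCOC(=O)[C@H](CCC(=O)O)NC(=O)c1ccc(Sc2nc3cc(N)cc(N)c3nc2-c2ccccc2)cc1` gives 95500 nM in this assay, and the two numbers lie within the usual scatter of each other, so they tell the same story. These two compounds differ in several places at once, so no single structural step can be read from the pair.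

Compound 3 `COc1ccc(CNc2nc3cc(N)cc(N)c3nc2-c2ccccc2)cc1OC` is the next compound to be measured. It differs from compound 1 in one place: 3,4-dimethoxyphenyl in place of 3,4-dichlorophenyl on a saturated chain carbon bound to a nitrogen on an aromatic ring. Going by the values given here, nothing measured so far shows what such an exchange does to the number, as no pair of measured compounds differs in only one place. With no guide from the measured compounds, the expected step, a 1.1-fold higher number from compound 1 to compound 3 (0.04 log units; within the scatter), stays within the scatter. Compound 3 is therefore expected to give about 60000 nM in this assay, with a likely range from 25000 nM to 150000 nM.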

Compound 3, concentration lethal to 50% of the cells: 91200 nM
The estimate for compound 3 lay 1.5-fold (0.18 log units) below the measured number; measured number inside the range.
By their numbers in this assay, from the lowest: compounds 1, 3 and 2 (each within the scatter of the next).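

In this assay, going by these compounds alone, the first step that changes only one place, a 1.7-fold higher number from compound 1 to compound 3 (0.22 log units; within the scatter), stays within the scatter, so compound 1 and compound 3 cannot be told apart. At this position, then, 3,4-dimethoxyphenyl, with 2 hydrogen-bond acceptors and 10 heavy atoms, can stand in place of 3,4-dichlorophenyl, with 0 hydrogen-bond acceptors and 8 heavy atoms, without a measurable change in the number, although this rests on a single exchange. No supporting measurement is available to explain why the number holds across this exchange.

As far as these compounds go, both groups are substituted six-membered aromatic rings of carbon only, so it remains open whether a cyclohexyl ring or a longer alkyl chain in this place would move the number beyond the scatter. Because all the numbers so far lie close together, the compounds shown also leave open whether any change at this position can shift the number in either direction.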